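Trimming the Cyclopropyl From the Core Side Chain

The compounds below may be only part of what the source reports. "The series", "measured", "known", "first", "only" and "open" are said of these compounds alone.

Compound 1 `CNC(=O)[C@@H](c1ccccc1)N1CCn2c(CC3CC3)nc(Cl)c2[C@@H]1CCc1ccc(C(F)(F)F)cc1`: 1430 nM
Compound 2 `CCOc1nc(CC)n2c1C(CCc1ccc(C(F)(F)F)cc1)N([C@@H](C(=O)NC)c1ccccc1)CC2`: 3980 nM
Compound 3 `CCc1nc(C(=O)N(C)C)c2n1CCN([C@@H](C(=O)NC)c1ccccc1)C2CCc1ccc(C(F)(F)F)cc1`: 344 nM

Of the compounds shown here, three sharing one core have been measured in a functional assay on CHO cells for antagonist activity at Orexin/Hypocretin receptor type 1 (Homo sapiens), read by FLIPR and calcium flux; a higher number here means a weaker inhibitor, a lower number a stronger inhibitor. Compound 1 stands second highest of the three numbers: compound 2 gives a higher number, beyond the scatter, and compound 3 gives a lower number, also beyond the scatter, so compound 1 sits between them.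

Compound 4 `CNC(=O)[C@@H](c1ccccc1)N1CCn2c(C)nc(Cl)c2[C@@H]1CCc1ccc(C(F)(F)F)cc1` is the unmeasured compound. It differs from compound 1 only by hydrogen in place of cyclopropyl on a saturated chain carbon bound to an aromatic carbon; cut one bond further out, the same difference reads cyclopropylmethyl to methyl. Among the compounds with values here, the single measured step, a 12-fold lower number from compound 2 to compound 3 (1.06 log units; beyond the scatter), concerns a different group at a different place, so it does not bear on this change. Within the data shown here, no measured pair isolates the cyclopropyl. With nothing to draw on, the expected step in this assay is small, most likely a slightly higher number and quite possibly within the scatter.

The estimate for compound 4 is therefore 2200 nM, with a range from 800 nM to 6500 nM, meaning an expected step of a 1.5-fold higher number from compound 1 to compound 4 (0.19 log units; within the scatter).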

Compound 4, half-maximal inhibitory concentration: 90 nM
For compound 4 the middle estimate is 24-fold (1.39 log units) above the measured one, outside the stated range (below it).
By their numbers in this assay, from the lowest: compound 4; then compound 3; then compound 1; then compound 2.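

In this assay, the side chain on the shared core proves far from neutral: hydrogen in place of cyclopropyl, which shortens cyclopropylmethyl to methyl, gives a 16-fold lower number from compound 1 to compound 4 (1.20 log units; beyond the scatter) and so a much stronger inhibitor. Within the data shown here, this is the first measured step at this position, and it shows that the cyclopropyl ring is not required for activity here and that the smaller methyl group performs better. No measurement shown here explains why this change has so large an effect.

The compounds shown do not reveal whether removing the ring or shortening the chain drives the step, which an open isobutyl chain could help separate. They also leave open how a polar group, such as a hydroxymethyl or an amine, would fare on this same carbon.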